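This account rests on a few compounds, and the source may have more. Where it says the series, first, only, none or still open, it means among the compounds named here.

Three compounds of the series have a number or a limit in an assay on cells for inhibition of HSP60/HSP10 (Homo sapiens), with a stated time of 60 min; a lower number here means a stronger inhibitor, a higher number a weaker inhibitor. Compound 1 `O=S(=O)(Nc1ccc(-c2nc3cc(NS(=O)(=O)c4ccccc4O)ccc3o2)cc1)c1ccccc1O` gives 18000 nM. Compound 3 `CS(=O)(=O)Nc1ccc(-c2nc3cc(NS(=O)(=O)c4ccc(Cl)s4)ccc3o2)cc1` gives 43000 nM. Compound 2 `O=S(=O)(Nc1ccc(-c2nc3ccccc3o2)cc1)c1ccccc1Cl` returns only a limit, > 100000 nM, so no number stands for it in this assay. Compound 2 thus sits at the limit of > 100000 nM in this assay, at which 1 of the 3 values shown sits, while compound 1 and compound 3 are the two with a reported number. Compound 2 and compound 4 differ at one place: fluoro in place of chloro on an aromatic carbon. Compound 4 `O=S(=O)(Nc1ccc(-c2nc3ccccc3o2)cc1)c1ccccc1F` is not yet measured in this assay. Going by the values given here, no pair of measured compounds differing at one place is available, so no measured step guides this change; what is known is that compound 2 itself gives only a limit. For the change from compound 2 to compound 4 no shift beyond the scatter is expected in either direction, and the most likely outcome is that compound 4 also returns only a limit rather than a number. Compound 4 is estimated at 150000 nM with a range of 40000 nM to 500000 nM. The step that this estimate means, a step that the limit leaves unreadable from compound 2 to compound 4, is expected to lie within the scatter.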

Compound 4, half-maximal inhibitory concentration: > 100000 nM
Compound 4 ended at the assay's limit (the forecaster's own chance of this, stated with the estimate: 70%); the middle value is on the limit's open side.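

Compound 4 returns > 100000 nM in this assay, a limit and not a number. Compound 2 returns > 100000 nM, likewise a limit, so no step can be read between compound 2 and compound 4. The compounds shown leave open how 2-chlorophenyl and 2-fluorophenyl compare in this assay, as neither compound carrying them has a number there.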